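A few compounds are considered here, and "the series" means these few. Any claim that something is new, unique, unknown or untested is made for them only; others in the source may bear on it.

Compounds measured in a functional assay on WiDr cells (Homo sapiens) for antiproliferative activity, read by sulforhodamine B assay, with a stated time of 48 h; on this read-out higher numbers stand for weaker inhibition of growth and lower numbers for stronger inhibition of growth:
- compound 1 `CC(C)(C)[Si](C)(C)O[C@@H]1CCCO[C@@H]1CO`: > 100000 nM (a limit of the assay, not a number)
- compound 2 `C=CCOC[C@H]1OCCC[C@H]1O[Si](C)(C)C(C)(C)C`: 88000 nM
- compound 3 `CC(C)(C)[Si](C)(C)O[C@@H]1CCCO[C@@H]1CO/C=C/C(=O)OCc1ccccc1`: 37000 nM

Compound 3 gives 37000 nM, the lowest number in this small set. Its nearest neighbour, compound 2, gives 88000 nM, a gap beyond the usual scatter. The next structure, compound 4 `COC(=O)/C=C/OC[C@H]1OCCC[C@H]1O[Si](C)(C)C(C)(C)C`, trades benzyl for methyl, which means hydrogen in place of phenyl on a saturated chain carbon bound to an oxygen next to a carbonyl group. Going by the values given here, the only measured step, an at least 1.1-fold lower number from compound 1 to compound 2 (0.05 log units; that floor lies within the scatter), is a different change, allyl in place of hydrogen, so it offers no direct guide. Compound 2 has no phenyl and gives 88000 nM, which loosely suggests that compound 4 will drift toward that number, meaning weaker inhibition of growth. The expected move is small: a 1.6-fold higher number from compound 3 to compound 4 (0.21 log units; within the scatter). In this assay, the estimate for compound 4 is 60000 nM, with an expected range from 25000 nM to 100000 nM.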

Compound 4, concentration for 50% growth inhibition: 36000 nM
Compound 4: the middle estimate sits 1.7-fold (0.22 log units) above what was measured; the range from low to high includes it.
By their numbers in this assay, from the lowest: compounds 4 and 3 (each within the scatter of the next); then compound 2. At a limit, above all of these: compound 1.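

Replacing benzyl with methyl in this assay gives a 1.0-fold lower number from compound 3 to compound 4 (0.01 log units; within the scatter), so the two compounds cannot be told apart and the phenyl group is not required for the growth inhibition seen in compound 3. Placing 2-(methoxycarbonyl)ethenyl in place of allyl on an oxygen on a saturated carbon gives a 2.4-fold lower number from compound 2 to compound 4 (0.39 log units; beyond the scatter), showing that this group still compares well with allyl when it carries only a small methyl ester. With hydrogen in place of that group the comparison is an at least 2.7-fold lower number from compound 1 to compound 4 (0.44 log units; beyond the scatter), but this is only a floor, since compound 1 stands at a limit: the limit of > 100000 nM in this assay, at which 1 of the 4 values shown sits.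

From the compounds shown here alone, it remains open whether the ester itself matters, which a carboxylic acid or an amide at that end would help to test. Going by these compounds, all four compounds also keep the same silyl ether on the shared core, so the effect of a free hydroxyl there is unknown.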